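Sulfonamide nitrogen substituent in amidinoindole acetamides

A few compounds are considered here, and "the series" means these few. Any claim that something is new, unique, unknown or untested is made for them only; others in the source may bear on it.

Measured compounds:
- compound 1, `CCOC(=O)C(CCc1cccc(C(=N)N)c1)Cn1cnc2ccc(C(=N)N)cc21`, 820 nM in an assay on isolated protein for binding affinity to serine protease 1 (Homo sapiens); a higher number here means a weaker inhibitor, a lower number a stronger inhibitor
- compound 2, `Cc1cc(-c2ccccc2S(N)(=O)=O)ccc1NC(=O)Cc1c[nH]c2ccc(C(=N)N)cc12`, 340 nM in this assay
- compound 3, `CNS(=O)(=O)c1ccccc1-c1ccc(NC(=O)Cc2c[nH]c3ccc(C(=N)N)cc23)cc1`, 120 nM in this assay

Compound 3 shows the lowest number of the three; its gap to compound 2 and its gap to compound 1 both lie beyond the scatter. Within the data shown here, compound 2 differs from compound 3 in more than one place, so no single step between measured compounds is available.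

Compound 4, `CCCNS(=O)(=O)c1ccccc1-c1ccc(NC(=O)Cc2c[nH]c3ccc(C(=N)N)cc23)cc1`, carries ethyl in place of hydrogen on a saturated chain carbon bound to a sulfonamide nitrogen. Among the measured compounds shown here, with no comparable step, the change is expected to stay small, within the scatter in either direction. Compound 4 is estimated at 110 nM, range 40 nM to 300 nM, meaning an expected step of a 1.1-fold lower number from compound 3 to compound 4 (0.04 log units; within the scatter).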

Compound 4, inhibition constant: 180 nM
Compound 4: middle estimate off by 1.6-fold (0.21 log units), on the low side, within the range that was stated.
By their numbers in this assay, from the lowest: compounds 3, 4 and 2 (each within the scatter of the next, the first and the last beyond it); then compound 1.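

Methylsulfamoyl to propylsulfamoyl gives the first single-place step in the series, a 1.5-fold higher number from compound 3 to compound 4 (0.18 log units; within the scatter), so in this assay this position takes the propyl chain without a change that can be told from the scatter. Nothing measured bears on why the step is this size.

Open, on these data alone, is whether a longer chain, a terminal amine or a carboxylic acid on this chain stays equally close to compound 3. As far as these compounds go, the separate contribution of the sulfonamide substituent in compound 2 also remains open, since that compound differs from compound 3 in more than one place.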